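Bromo on the phenol ring of a triazole-linked scaffold

The source may report more compounds than this note shows. Statements on the series, on what has been measured and on what is new or still open speak of the compounds shown alone.

Compound 1 `C=C1C[C@]23C[C@@]1(O)CC[C@H]2c1ccc(O)c(C)c1[C@@H]3Cn1cc(-c2ccccn2)nn1`: > 20000 nM
Compound 2 `C=C1C[C@]23C[C@@]1(O)CC[C@H]2c1ccc(O)c(C)c1[C@@H]3Cn1cc(-c2ccc(C(F)(F)F)cc2)nn1`: 12400 nM

Compound 1 carries a pyridin-2-yl on the triazole. In a functional assay on MCF7 cells (Homo sapiens) for cytotoxicity, read by MTT assay, with a stated time of 4 days (a lower number here means a stronger inhibitor, a higher number a weaker inhibitor), compound 1 gives only a limit, > 20000 nM (the limit of > 20000 nM in this assay, at which 1 of the 2 values shown sits). Within the data shown here, compound 2 bears 4-(trifluoromethyl)phenyl instead, and in this assay compound 2 gives 12400 nM, the only numerical value among the two compounds; the step of an at least 1.6-fold lower number from compound 1 to compound 2 (0.20 log units; that floor lies within the scatter) is the sole measured comparison. Compound 3 `C=C1C[C@]23C[C@@]1(O)CC[C@H]2c1cc(Br)c(O)c(C)c1[C@@H]3Cn1cc(-c2ccc(C(F)(F)F)cc2)nn1` differs from compound 2 by bromo in place of hydrogen on an aromatic carbon. Among the measured compounds shown here, no measured step touches this part of the shared core, so nothing among the measured compounds bears directly on the change; the expectation can only be that compound 3 stays near compound 2. The estimated step of a 1.4-fold lower number from compound 2 to compound 3 (0.14 log units; within the scatter) is expected to lie within the scatter. In this assay compound 3 is therefore estimated at 9000 nM, with a range from 2500 nM to 30000 nM.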

Compound 3, half-maximal inhibitory concentration: 8100 nM
Compound 3: middle estimate off by 1.1-fold (0.05 log units), on the high side, and the stated range covers the measured number.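

In this assay the result is a 1.5-fold lower number from compound 2 to compound 3 (0.18 log units; within the scatter), so bromo in place of hydrogen, ortho to the hydroxy group, brings no change that this assay can separate from repeat measurements. Unlike the earlier step, which lay on the triazole, this is the only measured step on the aromatic ring of the shared core, and it shows that this position can carry a bromine atom with the cytotoxicity reading unchanged within the scatter. Nothing shown gives a cause for this outcome.

From the compounds shown here alone, whether this position would respond in the same way to an amine, a methoxy group or a carboxylic acid remains open. Going by these compounds, it is also open whether bromo would behave alike with the pyridin-2-yl group on the triazole.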